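Chlorobenzyl Isomers in a Dihydropyrimidine Carboxamide Series

The compounds below may be only part of what the source reports. "The series", "measured", "known", "first", "only" and "open" are said of these compounds alone.

Measured compounds:
Compound 1, `COc1ccc(C2N=C(SCc3ccccc3Cl)NC(C)=C2C(=O)Nc2ccc(F)cc2)cc1OC`, gives 2.6%.
Compound 2, `COc1ccc(C2N=C(SCc3cccc(Cl)c3)NC(C)=C2C(=O)Nc2ccc(F)cc2)cc1OC`, gives 2.1%.
Compound 3, `CC1=C(C(=O)Nc2ccc(Br)cc2)C(c2ccc(Cl)cc2Cl)N=C(SCc2ccccc2Cl)N1`, gives 3.1%.

The three compounds were tested in a functional assay on the whole organism (artery, strain albino) with Rattus norvegicus as the target, with a stated time of 15 min, at a dose of 10 mg/kg by the oral route; on this read-out higher numbers stand for more inhibition at the one dose given (going by the name of the read-out) and lower numbers for less inhibition. The read-out is the size of the effect at the one dose given, not a potency.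

Compound 1 and compound 2 share one core and differ in a single place: 3-chlorophenyl in place of 2-chlorophenyl on a saturated chain carbon bound to a sulfur. Across this pair the read-out moved by a number 0.5 percentage points lower from compound 1 to compound 2 (within the scatter), so the two values cannot be told apart. Compound 3 carries a different core, and the difference between its core and that of compound 1 is not broken down here; what the numbers show is that compound 3 and compound 1 sit close to each other in this assay.

Compound 4, `CC1=C(C(=O)Nc2ccc(Br)cc2)C(c2ccc(Cl)cc2Cl)N=C(SCc2cccc(Cl)c2)N1`, has not yet been measured. It differs from compound 3 by the same kind of change that separates compound 2 from compound 1: 3-chlorophenyl in place of 2-chlorophenyl on a saturated chain carbon bound to a sulfur. The place line is the same in both pairs, a saturated chain carbon bound to a sulfur.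

Because the step of a number 0.5 percentage points lower from compound 1 to compound 2 (within the scatter) lay within the scatter, the same change on the core of compound 3 is expected to make a similarly small step, estimated at a number 0.5 percentage points lower from compound 3 to compound 4 (within the scatter). Compound 4 is therefore estimated to give 2.6% in this assay, with an expected range from -6% to 11%.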

Compound 4, a percentage reported as inhibition, in the whole organism at one dose (the size of the read-out at that dose, not a potency): 1.5%
For compound 4 the middle estimate is 1.1 percentage points above the measured one, and the stated range covers the measured number.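

In this assay, within the data shown here, the exchange of 2-chlorobenzyl for 3-chlorobenzyl on the core of compound 3 came out as a number 1.6 percentage points lower from compound 3 to compound 4 (within the scatter), so this second core also gives no step that can be told from the scatter. Set beside the earlier pair, the same exchange gives steps that cannot be told apart on the two cores: the same change on two cores in this assay, a number 0.5 percentage points lower (within the scatter) from compound 1 to compound 2 and a number 1.6 percentage points lower (within the scatter) from compound 3 to compound 4, 1.1 percentage points apart, within the scatter of two such steps. This shows only that, on these two cores and at this one dose, the exchange leaves the read-out within the usual scatter; it does not show that the change has a real effect of its own that carries over, nor does it show how the exchange would behave on any other core in the series or what it does to potency.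

The compounds shown leave open whether anything other than a chlorobenzyl group on the sulfur would move the read-out beyond the scatter, such as an unsubstituted benzyl group, a longer alkyl chain, or a chain ending in an amine or a carboxylic acid. They also leave open what each of the other differences between the two cores contributes, since those differences are not separated by any pair here.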